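A few compounds are considered here, and "the series" means these few. Any claim that something is new, unique, unknown or untested is made for them only; others in the source may bear on it.

In a functional assay with Mus musculus as the target (on this read-out lower numbers stand for stronger inhibition and higher numbers for weaker inhibition), compound 1 `N[C@@H]1CCCc2onc(O)c21` gives a measured value of 281000 nM. Compound 2 `NC1CCCc2snc(O)c21` yields no number on this read-out. Its result is only a limit, > 500000 nM. This is the position of the limit of > 500000 nM in this assay, at which 1 of the 2 values shown sits, so compound 2 has no exact place on the scale, and the size of any step starting from it can only be approximate.

The next compound to be tested is compound 3 `CNC1CCCc2snc(O)c21`, which has methyl in place of hydrogen on an amine nitrogen. The rest of the structure is unchanged from compound 2. Going by the values given here, no pair of measured compounds shows this same change, so there is no direct precedent for its effect in this assay. A modest move toward stronger inhibition is expected, although compound 3 could also end up reported only as a limit. The expected change is an at least 1.4-fold lower number from compound 2 to compound 3 (0.15 log units; that floor lies within the scatter). For compound 3 the estimate is 350000 nM, with an expected range from 120000 nM to 900000 nM.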

Compound 3, half-maximal inhibitory concentration: > 500000 nM
Compound 3 gave a limit, no number; the forecaster's own chance of this, stated with the estimate: 45%; middle value at least 1.4-fold (0.15 log units) from the limit.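

In this assay compound 3 gives > 500000 nM, which is a limit and not a number. Compound 2 also stands only at a limit, so no step can be read from compound 2 to compound 3: the limit of > 500000 nM in this assay, at which 2 of the 3 values shown sit. The compounds shown leave open whether methyl in place of hydrogen on an amine nitrogen changes inhibition at all.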